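Shortening the propyl chain of compound 3 to methyl

A few compounds are considered here, and "the series" means these few. Any claim that something is new, unique, unknown or untested is made for them only; others in the source may bear on it.

In a functional assay on U-87MG ATCC cells (Homo sapiens) for inhibition (on this read-out higher numbers stand for weaker inhibition and lower numbers for stronger inhibition), the measured compounds read as follows:
compound 1 `COc1cc(/C=C/C(=O)c2cccc(NC(=O)c3ccco3)c2)ccc1O` gives 6.65 ug/mL
compound 2 `COC(=O)C(=O)Nc1cccc(C(=O)/C=C/c2ccc(O)c(OC)c2)c1` gives 12.2 ug/mL
compound 3 `CCCC(=O)Nc1cccc(C(=O)/C=C/c2ccc(O)c(OC)c2)c1` gives 5.56 ug/mL

Going by the values given here, compound 3 sits at the low end of these numbers, but only one neighbour is truly separated from it. The data show a 1.2-fold lower number from compound 1 to compound 3 (0.08 log units; within the scatter) while they also show a 2.2-fold lower number from compound 2 to compound 3 (0.34 log units; beyond the scatter) on the same read-out.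

Compound 4 `COc1cc(/C=C/C(=O)c2cccc(NC(C)=O)c2)ccc1O` has not yet been measured. Its difference from compound 3 is hydrogen in place of ethyl on a saturated chain carbon bound to a carbonyl carbon and it reads equally as propyl to methyl or as (propylcarbonyl)amino to acetamido.

Among the compounds with values here, all three measured steps change the group at this same carbonyl carbon, so they are the only guide. The data show a 1.8-fold higher number from compound 1 to compound 2 (0.26 log units; within the scatter) as well, which makes furan-2-yl, methoxycarbonyl and propyl a narrow set in this assay overall. None of these steps swaps propyl for methyl, so the guide is indirect. Within the data shown here, only the step from methoxycarbonyl to propyl passes the scatter, and modestly. A step of similar or smaller size is therefore expected here, with no firm direction. The expected outcome is a 1.2-fold higher number from compound 3 to compound 4 (0.07 log units; within the scatter) and nothing beyond the scatter is anticipated. Compound 4 is estimated at 6.5 ug/mL with an expected range from 3.3 ug/mL to 12.5 ug/mL in this series.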

Compound 4, half-maximal inhibitory concentration: > 50 ug/mL
Compound 4 gave a limit, no number; the forecaster's own chance of this, stated with the estimate: 3%; at least 7.6-fold (0.88 log units) between middle value and limit.
By their numbers in this assay, from the lowest: compounds 3, 1 and 2 (each within the scatter of the next, the first and the last beyond it). At a limit, above all of these: compound 4.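

In this assay compound 4 gives no number, only a limit of the assay: the limit of > 50 ug/mL in this assay, at which 1 of the 4 values shown sits. Shortening propyl to methyl on this saturated chain yields an at least 8.9-fold higher number from compound 3 to compound 4 (0.95 log units; beyond the scatter), so the group at this carbonyl carbon can matter far more than furan-2-yl, methoxycarbonyl and propyl had suggested, as those three stayed within a narrow span of one another. The same separation appears against the other two groups, with an at least 7.5-fold higher number from compound 1 to compound 4 (0.87 log units; beyond the scatter) and an at least 4.0-fold higher number from compound 2 to compound 4 (0.61 log units; beyond the scatter), which sets methyl apart from all three earlier groups, even though the part that leaves compound 3 is only an ethyl of 2 carbon atoms with no ring and no hydrogen-bond donors or acceptors.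

The compounds shown leave open whether an ethyl group on this carbonyl carbon would stay with propyl or fall with methyl, and whether a longer chain such as butyl or pentyl would carry the numbers lower than in compound 3. They also give no reason for the separation of compound 4, and they cannot say whether a ring such as cyclopropyl would behave like propyl here.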